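The compounds below may be only part of what the source reports. "The series", "measured", "known", "first", "only" and "open" are said of these compounds alone.

Measured in a functional assay on MCF7 cells (Homo sapiens) for antiproliferative activity, read by MTT assay, with a stated time of 48 h; on this read-out lower numbers stand for stronger inhibition and higher numbers for weaker inhibition:

compound 1 `COc1ccc(OC(=O)C#Cc2ccccc2)cc1` gives 52600 nM
compound 2 `O=C1C=CC2(C=C1)OC(=O)C(c1cc3ccccc3o1)=C2c1ccccc1` gives 5800 nM
compound 3 `COc1cc(C2=C(c3ccccc3)C3(C=CC(=O)C=C3)OC2=O)cc(OC)c1OC` gives 5790 nM

Among these three numbers compound 2 stands second highest. Its nearest neighbour is compound 3, whose number lies within the usual scatter of compound 2, so the two cannot be told apart. Its furthest neighbour is compound 1, whose number is beyond the scatter and higher, meaning weaker inhibition than compound 2 in this assay.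

Compound 4 `COc1ccc(F)cc1C1=C(c2ccccc2)C2(C=CC(=O)C=C2)OC1=O` has not yet been measured. It differs from compound 2 in one place: 5-fluoro-2-methoxyphenyl in place of 1-benzofuran-2-yl on a double-bonded ring carbon. Among the measured compounds shown here, no measured pair shows this particular change directly. What the data do show is that compound 3, which carries a different aryl group at the same position, gives a number indistinguishable from that of compound 2. On that basis the expected step from compound 2 to compound 4 is a 1.0-fold higher number from compound 2 to compound 4 (0.01 log units; within the scatter), that is, none beyond the scatter in either direction. Compound 4 is therefore estimated at 6000 nM in this assay, with a likely range from 2500 nM to 15000 nM.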

Compound 4, half-maximal inhibitory concentration: 5730 nM
For compound 4 the middle estimate is 1.0-fold (0.02 log units) above the measured one; the measured number falls inside the stated range.
By their numbers in this assay, from the lowest: compounds 4, 3 and 2 (each within the scatter of the next); then compound 1.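

In this assay, the change from 1-benzofuran-2-yl to 5-fluoro-2-methoxyphenyl on this double-bonded ring carbon gives a 1.0-fold lower number from compound 2 to compound 4 (0.01 log units; within the scatter) and so cannot be told apart from no change at all. Among the compounds shown here, this is the first direct reading of a swap at this position: a group with a five-membered and a six-membered aromatic ring gives way to one with a single six-membered aromatic ring, bearing fluoro and methoxy groups, with no step beyond the scatter. Nothing measured here accounts for why these two groups read alike.

The compounds shown leave open whether this position also tolerates a non-aromatic group, such as an amine, a carboxylic acid or a longer alkyl chain. They also leave open how a replacement of the phenyl group on the neighbouring ring atom that bears it would read.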